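Swapping Isobutyl for Isopropoxy on a Silent Scaffold

A few compounds are considered here, and "the series" means these few. Any claim that something is new, unique, unknown or untested is made for them only; others in the source may bear on it.

Compound 2 `Cc1cc(CCC(=O)O)ccc1-c1noc(-c2ccc(CC(C)C)nc2)n1` carries a propanoic acid chain on one ring and an isobutyl group on the six-membered aromatic ring with one nitrogen. In a functional assay on CHO cells with sphingosine 1-phosphate receptor 2 (Homo sapiens) as the target, read by GTPgammaS binding (a lower number here means that less compound is needed, a higher number that more compound is needed for the effect), compound 2 gives > 10000 nM, which is a limit of the assay rather than a number. Compound 1 `Cc1cc(CCC(=O)O)ccc1-c1noc(-c2ccc(OC(C(F)(F)F)C(F)(F)F)c(C#N)c2)n1` shares the same core and stands in the same place: in this assay compound 1 gives > 10000 nM, again a limit and not a number. For the measured compounds named here, both values sit at the limit of > 10000 nM in this assay, at which 2 of the 2 values shown sit, so there is no measured step between compounds, and nothing here separates the two.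

Compound 3 `Cc1cc(CCC(=O)O)ccc1-c1noc(-c2ccc(OC(C)C)nc2)n1` is the unmeasured partner of compound 2. The change is isopropoxy in place of isobutyl on an aromatic carbon.

Going by the values given here, with compound 2 resting at a limit, no measured step is available to lean on. The expectation is that the step that the limit leaves unreadable from compound 2 to compound 3 is none beyond the scatter, so that compound 3 most likely also returns a limit. The estimate for compound 3 in this assay is 15000 nM, with a range from 4000 nM to 60000 nM.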

Compound 3, half-maximal effective concentration: > 10000 nM
Compound 3 ended at the assay's limit (the forecaster's own chance of this, stated with the estimate: 80%); the middle value lies beyond the limit too.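

In this assay compound 3 gives > 10000 nM, a limit of the assay and not a number. Compound 2 also rests at a limit, so no step can be read between compound 2 and compound 3. The compounds shown leave open what value lies behind each limit, and so whether this swap changes anything in this assay.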